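The compounds below may be only part of what the source reports. "The series", "measured", "known", "first", "only" and "open" are said of these compounds alone.

Measured so far:
- compound 1 `CC(NC(=O)c1cccc(-c2ccc(NC(=O)Nc3ccc(Cl)c(C(F)(F)F)c3)cc2)c1)c1ccccc1` — 5240 nM
- compound 2 `CNC(=O)/C(C)=C/c1ccc(NC(=O)Nc2ccc(Cl)c(C(F)(F)F)c2)cc1` — limit, > 50000 nM
- compound 3 `C/C(=C\c1ccc(NC(=O)Nc2ccc(Cl)c(C(F)(F)F)c2)cc1)C(=O)N1CC(C)OC(C)C1` — limit, > 50000 nM

In a functional assay on MX1 cells (Homo sapiens) for inhibition, read by MTT assay, with a stated time of 120 h (on this read-out lower numbers stand for stronger inhibition and higher numbers for weaker inhibition), compound 1 gives 5240 nM. Compound 2 reaches only the limit of the assay, > 50000 nM. Compound 3 likewise returns only a limit, > 50000 nM. The step that the two limits leave unreadable from compound 2 to compound 3 is therefore not readable; both compounds sit at the limit of > 50000 nM in this assay, at which 2 of the 3 values shown sit. Among the measured compounds shown here, compound 2 thus stands at the limit, with compound 3 beside it, and compound 1 is the only measured number in the set.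

Compound 4 `O=C(/C=C/c1ccc(NC(=O)Nc2ccc(Cl)c(C(F)(F)F)c2)cc1)NC1CCC1` has not been measured. It differs from compound 2 by 2-(cyclobutylcarbamoyl)ethenyl in place of 2-(methylcarbamoyl)prop-1-en-1-yl on an aromatic carbon. For the measured compounds named here, no measured step bears directly on this change: the one step within the shared core is the unreadable one from compound 2 to compound 3, and compound 1 belongs to a different linker. With compound 2 at the limit, compound 4 is expected to stay weak; the step of an at least 1.2-fold lower number from compound 2 to compound 4 (0.09 log units; that floor lies within the scatter) is expected to be small or unreadable. Compound 4 is estimated at 40000 nM, between 8000 nM and 100000 nM.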

Compound 4, half-maximal inhibitory concentration: 4530 nM
Estimate against measurement, compound 4: 8.8-fold (0.95 log units) above; the measured number lies below the stated range.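

In this assay, 2-(cyclobutylcarbamoyl)ethenyl in place of 2-(methylcarbamoyl)prop-1-en-1-yl, on the aromatic carbon para to a large group, gives an at least 11-fold lower number from compound 2 to compound 4 (1.04 log units; beyond the scatter). Among the compounds shown here, this is the first readable step within the shared core, and it shows that a change at this position can bring a measurable value, with compound 4 at 4530 nM. The earlier step between the two limits cannot be read. The true size of the step remains unknown, and the printed size is only a floor, because compound 2 is a limit: the limit of > 50000 nM in this assay, at which 2 of the 4 values shown sit.

Still open, from the compounds shown here alone, is how the step divides between the two parts of the change, the methyl lost from the chain and the cyclobutyl in place of methyl on the carbamoyl. Also open, going by these compounds, is how a cyclopentyl group on the carbamoyl, or a carboxylic acid in place of the whole amide, would read here.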